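Swapping bromo for hydroxy on a shared core

The compounds below may be only part of what the source reports. "The series", "measured", "known", "first", "only" and "open" are said of these compounds alone.

Of the compounds shown here, two sharing a core have been measured in an assay on HEK293 cells for inhibition of N-acylethanolamine-hydrolyzing acid amidase (Rattus norvegicus), read by LC-MS, with a stated time of 30 min; a higher number here means a weaker inhibitor, a lower number a stronger inhibitor. Compound 1 `O=C(CCCCCc1cccc(Br)c1)N1CCOC1=O` gives 430 nM, the higher of the two numbers. Compound 2 `O=C(CCCCCc1ccc(O)c(F)c1)N1CCOC1=O` gives 160 nM, a lower number, and the gap between the two lies beyond the usual scatter of repeated measurements. These two compounds differ in more than one place, so their values show only where each stands, not what any single change does.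

Compound 3 `O=C(CCCCCc1cccc(O)c1)N1CCOC1=O` has not yet been measured. It differs from compound 1 by hydroxy in place of bromo on an aromatic carbon. Among the compounds with values here, no pair of measured compounds differs in one place alone, so the size of this step is unknown. Compound 2, which also carries a hydroxy, gives a lower number, 160 nM, than compound 1; on that basis compound 3 is expected to give a modestly lower number than compound 1, a step of a 1.7-fold lower number from compound 1 to compound 3 (0.24 log units; within the scatter). Compound 3 is estimated at 250 nM in this assay, within a range from 80 nM to 800 nM.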

Compound 3, half-maximal inhibitory concentration: 8640 nM
Compound 3: the middle estimate sits 35-fold (1.54 log units) below what was measured; the whole stated range lies below it.
By their numbers in this assay, from the lowest: compound 2; then compound 1; then compound 3.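

In this assay the swap of bromo for hydroxy on an aromatic carbon brings a 20-fold higher number from compound 1 to compound 3 (1.30 log units; beyond the scatter) and is the only single change shown so far. It shows that this place on the ring, meta to a large group, is far from indifferent to what it carries: replacing one heavy atom, with a hydrogen-bond donor and acceptor entering, is enough to make a much weaker inhibitor. Nothing available here explains why the step is so large.

The compounds shown leave open whether the weakening follows from hydroxy entering or from bromo leaving, which methoxy, chloro or an amine at this same place could help to separate. They also leave open whether the step would keep its size with a longer chain.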